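A few compounds are considered here, and "the series" means these few. Any claim that something is new, unique, unknown or untested is made for them only; others in the source may bear on it.

Compound 2 `Cc1cc2nn(-c3ccc(Br)cc3)c(C)c2c(=O)o1` stands at 59.5% in a functional assay on the whole organism for inhibition, with Rattus norvegicus as the target, read by paw edema, with a stated time of 1 h, at a dose of 50 mg/kg (a higher number here means more inhibition at the dose given (going by the name of the read-out), a lower number less inhibition), within the scatter of compound 1 `Cc1cc2nn(-c3ccc(Cl)cc3)c(C)c2c(=O)o1`, which in this assay gives 58.2%. Within the data shown here, the only measured step, a number 1.3 percentage points higher from compound 1 to compound 2 (within the scatter), lies within the scatter. Compound 3 `COc1ccc(-n2nc3cc(C)oc(=O)c3c2C)cc1` arises from compound 2 by methoxy in place of bromo on an aromatic carbon. Among the measured compounds shown here, no measured step exchanges a halogen for methoxy, so the one halogen step offers only weak guidance; as it was flat, no step beyond the scatter is expected, and the estimated step is a number 4.5 percentage points lower from compound 2 to compound 3 (within the scatter). Compound 3 is therefore expected to give 55%, with a range from 40% to 68%.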

Compound 3, a percentage reported as inhibition, in the whole organism at one dose (the size of the read-out at that dose, not a potency): 64.6%
Estimate against measurement, compound 3: 9.6 percentage points below; measured number inside the range.
By their numbers in this assay, from the lowest: compounds 1, 2 and 3 (each within the scatter of the next).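

Methoxy in place of bromo gives a number 5.1 percentage points higher from compound 2 to compound 3 (within the scatter), and methoxy in place of chloro gives a number 6.4 percentage points higher from compound 1 to compound 3 (within the scatter), so neither change moves the number beyond the scatter. The earlier compounds shown here compared only two halogens; in this assay this position, para to a large group, now also holds a non-halogen group with one hydrogen-bond acceptor, and the numbers stay level. Going by these compounds, whether an amine, a carboxylic acid or a longer alkoxy chain here would leave the number level remains open. Nothing available explains why the three compounds read alike.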